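This account rests on a few compounds, and the source may have more. Where it says the series, first, only, none or still open, it means among the compounds named here.

In a functional assay on U-87MG ATCC cells for cytotoxicity against U-87 MG (Homo sapiens), read by MTT assay, with a stated time of 72 h (on this read-out higher numbers stand for weaker inhibition and lower numbers for stronger inhibition), compound 2 `COc1ncc(-c2ccc3nc(NC(=O)NCC(=O)N4CCCC4)nn3c2)cc1NS(=O)(=O)c1ccc(F)cc1` gives 1000 nM. That value lies within the scatter of both compound 1 `COc1ncc(-c2ccc3nc(NC(=O)NCC(=O)N4CCCCC4)nn3c2)cc1NS(=O)(=O)c1ccc(F)cc1` at 740 nM and compound 3 `CCN(CC)CCNC(=O)Nc1nc2ccc(-c3cnc(OC)c(NS(=O)(=O)c4ccc(F)cc4F)c3)cn2n1` at 1060 nM, so compound 2 has no clear rank among the three.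

The next change leads to compound 4 `COc1ncc(-c2ccc3nc(NC(=O)NCCN4CCN(C)CC4)nn3c2)cc1NS(=O)(=O)c1ccc(F)cc1`: (4-methylpiperazin-1-yl)methyl in place of (pyrrolidin-1-yl)carbonyl on a saturated chain carbon bound to an amide-type nitrogen. Cut one bond further out, this reads (((pyrrolidin-1-yl)carbonyl)methyl)carbamoyl to (2-(4-methylpiperazin-1-yl)ethyl)carbamoyl.

Among the compounds with values here, only one measured step bears directly on this part of the molecule. That step, a 1.4-fold higher number from compound 1 to compound 2 (0.13 log units; within the scatter), stays within the scatter, but it only exchanges one ring on the carbonyl carbon for another. It says nothing about removing the carbonyl, which is what compound 4 does. Compound 3 offers indirect evidence: it also lacks a carbonyl at this place in the chain and gives 1060 nM, but it differs from compound 2 elsewhere too, so it is only a rough guide.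

On this evidence, no step beyond the scatter is expected in this assay, in either direction. Within the data shown here, the expected change is a 1.1-fold lower number from compound 2 to compound 4 (0.05 log units; within the scatter), and the range is kept wide because no measured step covers this exact change. For compound 4 the estimated value is 900 nM, with an expected range of 300 nM to 2700 nM.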

Compound 4, half-maximal inhibitory concentration: 760 nM
Compound 4: the middle estimate sits 1.2-fold (0.07 log units) above what was measured; the measured number falls inside the stated range.
By their numbers in this assay, from the lowest: compounds 1, 4, 2 and 3 (each within the scatter of the next).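

In this assay, (4-methylpiperazin-1-yl)methyl in place of (pyrrolidin-1-yl)carbonyl gives a 1.3-fold lower number from compound 2 to compound 4 (0.12 log units; within the scatter), and in place of (piperidin-1-yl)carbonyl it gives a 1.0-fold higher number from compound 1 to compound 4 (0.01 log units; within the scatter), so the read-out stays within the scatter on both steps. The earlier step only exchanged one ring on the carbonyl carbon, whereas these two steps show that, for this pair of groups, the carbonyl can be lost from this saturated chain at the same time as the ring changes without a step beyond the scatter, although the two changes cannot be separated here. Nothing available accounts for this flat result.

With compounds 1, 2 and 4 all within the scatter of one another, these compounds do not yet show whether any group at this place can shift the read-out beyond the scatter. A carboxylic acid at the end of the chain, a morpholine ring on the same 2-substituted ethyl chain, a primary amine, or a longer chain ahead of the 4-methylpiperazin-1-yl ring would each test this, and the same group on a carbonyl and on a saturated carbon would separate the ring change from loss of the carbonyl.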